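Lengthening the chain: compound 3 to compound 4

The source may hold more compounds than are shown below. What is called first, only, known or untested is meant among the compounds shown, and "the series" means these compounds.

Compound 1 `NCCNc1ccnc2cc(Cl)ccc12`: 7220 nM
Compound 2 `NCCCNc1ccnc2cc(Cl)ccc12`: 9830 nM
Compound 3 `NCCCCNc1ccnc2cc(Cl)ccc12`: 11200 nM

All three values come from a functional assay on HeLa cells (Homo sapiens) for cytotoxicity, read by MTT assay, with a stated time of 7 days; on this read-out higher numbers stand for weaker inhibition and lower numbers for stronger inhibition. Compound 3 cannot be separated from the other two, since a 1.6-fold higher number from compound 1 to compound 3 (0.19 log units; within the scatter) and a 1.1-fold higher number from compound 2 to compound 3 (0.06 log units; within the scatter) both stay within the scatter, as does a 1.4-fold higher number from compound 1 to compound 2 (0.13 log units; within the scatter).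

The next compound is compound 4 `NCCCCCCNc1ccnc2cc(Cl)ccc12`, reached by 2-aminoethyl in place of amino on a saturated chain carbon, four bonds along the chain from a nitrogen on an aromatic ring. Within the data shown here, the nearest precedent is the same exchange two bonds along the chain, a 1.6-fold higher number from compound 1 to compound 3 (0.19 log units; within the scatter). No step beyond the scatter is therefore expected in this assay. The expected change is a 1.1-fold higher number from compound 3 to compound 4 (0.03 log units; within the scatter). The estimate for compound 4 is 12000 nM, with an expected range of 6500 nM to 22000 nM.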

Compound 4, half-maximal inhibitory concentration: 15700 nM
Beside the measured number, compound 4's estimate is 1.3-fold (0.12 log units) below it; measured number inside the range.
By their numbers in this assay, from the lowest: compounds 1, 2, 3 and 4 (each within the scatter of the next, the first and the last beyond it).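

In this assay the series reaches its first pair beyond the scatter with a 2.2-fold higher number from compound 1 to compound 4 (0.34 log units; beyond the scatter) and this step is modest, whereas a 1.4-fold higher number from compound 3 to compound 4 (0.15 log units; within the scatter) and a 1.6-fold higher number from compound 2 to compound 4 (0.20 log units; within the scatter) stay within it. Lengthening the chain at this position thus separates only the two ends of the series, and none of the shorter steps can be told apart on its own. No evidence on the cause of the step is available here.

On these data alone, whether a longer chain would widen the gap remains open. So does whether a carboxylic acid in place of the amine would change the number at all.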